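A Furan Replaces the Thiophene on the Amine

The source may hold more compounds than are shown below. What is called first, only, known or untested is meant among the compounds shown, and "the series" means these compounds.

Compound 2 `CN(Cc1ccsc1)C1CCN(CCCc2c[nH]c3ccc(-n4cnnc4)cc23)CC1` gives 35 nM in an assay on CHO cells for displacement of a labelled ligand from 5-hydroxytryptamine receptor 1B (Homo sapiens) (a lower number here means a stronger inhibitor, a higher number a weaker inhibitor), the lower of the two numbers available; its nearest neighbour, compound 1 `c1ccc2c(c1)CCC2NC1CCN(CCCc2c[nH]c3ccc(-n4cnnc4)cc23)CC1`, gives 280 nM. Among the compounds with values here, the only measured step, an 8.0-fold lower number from compound 1 to compound 2 (0.90 log units; beyond the scatter), concerns a different part of the molecule. Compound 3 `CN(Cc1ccco1)C1CCN(CCCc2c[nH]c3ccc(-n4cnnc4)cc23)CC1` differs from compound 2 by furan-2-yl in place of thiophen-3-yl on a saturated chain carbon bound to an amine nitrogen. Within the data shown here, no measured step tests this exchange of one five-membered aromatic ring for another, so no movement beyond the scatter is expected. For compound 3 the step is estimated at a 1.3-fold higher number from compound 2 to compound 3 (0.11 log units; within the scatter). Compound 3 is therefore expected to give 45 nM, within 18 nM to 110 nM.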

Compound 3, half-maximal inhibitory concentration: 89 nM
Beside the measured number, compound 3's estimate is 2.0-fold (0.30 log units) below it; the range from low to high includes it.
By their numbers in this assay, from the lowest: compound 2; then compound 3; then compound 1.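

At the saturated chain carbon bound to an amine nitrogen, the choice of five-membered aromatic ring matters in this assay, where furan-2-yl in place of thiophen-3-yl gives a 2.5-fold higher number from compound 2 to compound 3 (0.41 log units; beyond the scatter) as a measurable loss. The larger amino exchange still holds up with the furan, showing a 3.1-fold lower number from compound 1 to compound 3 (0.50 log units; beyond the scatter) in a smaller gain than thiophen-3-yl gave. Nothing available explains the loss. From the compounds shown here alone, the step changes both the hetero atom and the point of attachment, and which of the two matters remains open. Thiophen-2-yl or furan-3-yl at this position would separate them.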